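The source may hold more compounds than are shown below. What is called first, only, known or untested is meant among the compounds shown, and "the series" means these compounds.

In an ADME assay (liver) for metabolic stability, with Liver microsome (Homo sapiens) as the target, using microsomes (on this read-out higher numbers stand for a longer-lived compound and lower numbers for a shorter-lived compound), compound 1 `Cc1noc(C)c1-c1ccc(-c2nc(C)c([C@H](OC(C)(C)C)C(=O)O)c(-c3ccc4c(c3)CCCO4)c2C)c(F)c1` gives 1 h. Compound 2 `Cc1ccc(-c2nc(C)c([C@H](OC(C)(C)C)C(=O)O)c(-c3ccc4c(c3)CCCO4)c2C)cc1` gives 0.717 h. These two numbers lie within the usual scatter of repeated measurements, so the data cannot separate them, and compound 2 stands level with compound 1 on this short record.

Compound 3 `Cc1ccc(-c2nc(C)c([C@H](OC(C)(C)C)C(=O)O)c(-c3ccc4c(c3)CCCO4)c2C)cc1C` has not yet been measured in this assay. It differs from compound 2 in one place: methyl in place of hydrogen on an aromatic carbon. This is methyl in place of hydrogen on an aromatic carbon, ortho to a methyl group, so that 4-methylphenyl becomes 3,4-dimethylphenyl.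

Going by the values given here, no measured pair here shows what such a change does to the half-life, so the expectation starts from compound 2 at 0.717 h. Only one carbon is added, and no shift beyond the scatter is expected, though a slightly shorter half-life seems the likelier direction. The estimated move is a 1.2-fold lower number from compound 2 to compound 3 (0.08 log units; within the scatter), which would stay within the scatter. For compound 3 the estimated half-life is 0.6 h, with an expected range from 0.3 h to 1.2 h.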

Compound 3, half-life: 0.567 h
Estimate against measurement, compound 3: 1.1-fold (0.02 log units) above; measured number inside the range.
By their numbers in this assay, from the lowest: compounds 3, 2 and 1 (each within the scatter of the next).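

In this assay, going by these compounds alone, the step from 4-methylphenyl to 3,4-dimethylphenyl is a 1.3-fold lower number from compound 2 to compound 3 (0.10 log units; within the scatter) and gives the first direct reading of a single change. At this place on the ring, ortho to a methyl group, one added methyl leaves the two half-lives indistinguishable, so this small addition neither clearly shortens nor clearly lengthens the compound's life in the assay. Within the data shown here, this is one pair at one position, so it describes only this change and sets no rule for the series. Nothing measured here explains why the half-life stays within the scatter.

Going by these compounds, what remains open is whether this place on the ring tolerates other groups as readily, for example a longer chain such as ethyl, a methoxy group, a chlorine atom or an amine, any of which could show a step beyond the scatter. On these data alone, it is also open whether the same methyl would leave the half-life just as unmoved on another carbon of this ring or alongside a different group in place of the existing methyl.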